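The compounds below may be only part of what the source reports. "The series", "measured", "known", "first", "only" and "open" are said of these compounds alone.

In a functional assay on RAW264.7 cells (Mus musculus) for inhibition, read by Griess assay, with stated times of 2 h and 18 h (a higher number here means a weaker inhibitor, a lower number a stronger inhibitor), two compounds have been tested so far. Compound 1 `CC1=C(CCC2=CCOC2=O)[C@@]2(C)CC[C@@H](O)C(C)(C)C2=C(O)C1=O` reads > 50000 nM, and this is a limit of the assay, not a number. Among the measured compounds shown here, compound 2 `CCC(=O)[C@H]1O[C@@](CCC2=CC(OC)OC2=O)(OC)[C@@]2(C)CCCC(C)(C)[C@H]12` gives 3900 nM, which makes it the only compound with a true number so far. Its standing therefore rests on one value and one limit, and the two compounds differ in more than one place, so they give no clean measure of any single change.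

Compound 3 `CCC(=O)[C@H]1O[C@](O)(CCC2=CC(OC)OC2=O)[C@@]2(C)CCCC(C)(C)[C@H]12` departs from compound 2 at a single place: hydrogen in place of methyl on an oxygen on a saturated carbon. This puts hydrogen in place of methyl on an oxygen on a saturated carbon, a change from methoxy to hydroxy, and the rest of the structure stays the same.

For the measured compounds named here, no measured pair shows this change in this assay, so the expectation starts from compound 2 at 3900 nM and stays cautious. A small step toward weaker inhibition is expected, and it may not exceed the usual scatter. The expected step of a 1.4-fold higher number from compound 2 to compound 3 (0.15 log units; within the scatter) is only an estimate. For compound 3 the estimated value is 5500 nM, with an expected range from 2000 nM to 18000 nM.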

Compound 3, half-maximal inhibitory concentration: 15700 nM
Compound 3: middle estimate off by 2.9-fold (0.46 log units), on the low side; the range from low to high includes it.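

Among the compounds shown here, the comparison of compound 2 with compound 3 is the first in this assay between compounds that differ in one place, and it shows that the group on this oxygen counts: methoxy to hydroxy gives a 4.0-fold higher number from compound 2 to compound 3 (0.60 log units; beyond the scatter). The earlier compounds shown here could not show this, as they differ in more than one place and only one of them has a true number. Compound 3 still gives a true number rather than a limit of the assay, so at this position the change weakens inhibition without carrying it out of the measured range, and nothing shown bears on why the step has this size.

As far as these compounds go, whether an ethoxy group or a longer chain on the same oxygen would read closer to compound 2 or to compound 3 remains open, as does the reading for an amine in place of the hydroxy group. This change is also seen in a single pair, so whether it would give a step of similar size on another core, or in another assay, cannot be said from these compounds.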